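A few compounds are considered here, and "the series" means these few. Any claim that something is new, unique, unknown or untested is made for them only; others in the source may bear on it.

Measured so far:
- compound 1 `CN1C(=O)S/C(=C\C2=Cc3ccccc3OC2)C1=O`: in a functional assay on A549 cells (Homo sapiens) for antiproliferative activity, read by MTT assay, with a stated time of 72 h (on this read-out lower numbers stand for stronger inhibition and higher numbers for weaker inhibition), compound 1 gives only a limit, > 100000 nM.
- compound 2 `CCN1C(=O)S/C(=C\C2=Cc3ccccc3OC2)C1=O`: in this assay compound 2 gives only a limit, > 200000 nM.
- compound 3 `CC1Oc2ccc(Br)cc2C=C1/C=C1\SC(=O)N(C)C1=O`: in this assay compound 3 gives only a limit, > 50000 nM.

The change from compound 1 to compound 2 is methyl in place of hydrogen on a saturated chain carbon bound to an amide-type nitrogen in a ring. Its step, a step that the two limits leave unreadable from compound 1 to compound 2, cannot be sized because the limit of > 100000 nM in this assay, at which 1 of the 3 values shown sits, and the limit of > 200000 nM in this assay, at which 1 of the 3 values shown sits, are both limits. Compound 4 `CCN1C(=O)S/C(=C\C2=Cc3cc(Br)ccc3OC2C)C1=O` carries the same change on the core of compound 3, (methyl in place of hydrogen on a saturated chain carbon bound to an amide-type nitrogen in a ring); the difference between the two cores is not broken down here. As compound 3 sits at the limit of > 50000 nM in this assay, at which 1 of the 3 values shown sits, and the earlier step gave no readable size, compound 4 is expected to give a limit again, so the expected step that the limit leaves unreadable from compound 3 to compound 4 is near nil. The estimate for compound 4 in this assay is 150000 nM, expected between 40000 nM and 800000 nM.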

Compound 4, half-maximal inhibitory concentration: > 100000 nM
Compound 4 was reported as a limit; the forecaster's own chance of this, stated with the estimate: 85%; the middle value does not contradict the limit.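

Compound 3 and compound 4 are both reported only as limits in this assay, so no step can be read between them. The compounds shown leave open whether the change from methyl to ethyl shifts activity at all.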